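From 1,3-oxazol-5-yl to methyl on a carbonyl carbon

This account rests on a few compounds, and the source may have more. Where it says the series, first, only, none or still open, it means among the compounds named here.

Measured so far in an ADME assay on microsomes (Rattus norvegicus) for metabolic stability; a higher number here means that the compound lasts longer, a lower number that the compound disappears faster
compound 1 `O=C(c1cnco1)N1CCC(C(=O)N2N=CC[C@H]2c2ccccc2)CC1` gives > 3 h
compound 2 `C[C@@H]1C=NN(C(=O)C(C)(C)C)[C@@H]1c1ccccc1` gives 0.2 h

Compound 1 stands at the limit of > 3 h in this assay, at which 1 of the 2 values shown sits, and its reading of > 3 h is a limit, not a number. Compound 2 gives a measured number, well short of that limit. Compound 3 `CC(=O)N1CCC(C(=O)N2N=CC[C@H]2c2ccccc2)CC1` keeps the core of compound 1 and carries methyl in place of 1,3-oxazol-5-yl on a carbonyl carbon. Going by the values given here, no two measured compounds differ in one place, so no measured step sizes this change, and the true starting value is unknown. A small downward step or none beyond the scatter is expected in this assay, and the estimated step runs an at least 1.2-fold lower number from compound 1 to compound 3 (0.07 log units; that floor lies within the scatter) on that reading. Compound 3 is estimated at 2.5 h with an expected range from 1 h to 6 h and may itself return only a limit.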

Compound 3, half-life: > 2.75 h
Compound 3 gave a limit, no number; the forecaster's own chance of this, stated with the estimate: 45%; middle value at least 1.1-fold (0.04 log units) from the limit.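

Compound 1 and compound 3 both return only limits in this assay, and no step can be read between them for methyl in place of 1,3-oxazol-5-yl on a carbonyl carbon. The compounds shown leave open the actual half-life of either compound and whether this change moves it at all.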